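From Methoxyphenyl to a Trifluoromethyl Pyrazole

This account rests on a few compounds, and the source may have more. Where it says the series, first, only, none or still open, it means among the compounds named here.

In a functional assay on MDA-MB-436 cells (Homo sapiens) for antiproliferative activity, read by MTT assay, with a stated time of 48 h (on this read-out lower numbers stand for stronger inhibition and higher numbers for weaker inhibition), compound 1 `C=CS(=O)(=O)N1CCN(c2ncnc3sc(-c4ccc(C(F)(F)F)cc4)cc23)CC1` gives 7080 nM, while compound 2 `C=CS(=O)(=O)N1CCN(c2ncnc3sc(-c4ccc(OC)cc4)cc23)CC1` gives 28400 nM, the higher of the two numbers. Compound 3 `C=CS(=O)(=O)N1CCN(c2ncnc3sc(-c4cn(C)nc4C(F)(F)F)cc23)CC1` keeps the shared core but changes one group: 1-methyl-3-(trifluoromethyl)-1H-pyrazol-4-yl in place of 4-methoxyphenyl on an aromatic carbon. Within the data shown here, only one measured step bears on this, a 4.0-fold higher number from compound 1 to compound 2 (0.60 log units; beyond the scatter), with methoxy in place of trifluoromethyl, and compound 3 carries trifluoromethyl again, though on a different ring. A smaller step toward a lower number is therefore expected: a 2.4-fold lower number from compound 2 to compound 3 (0.37 log units; beyond the scatter). The estimate for compound 3 is 12000 nM, with an expected range from 4500 nM to 30000 nM.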

Compound 3, half-maximal inhibitory concentration: 15100 nM
Beside the measured number, compound 3's estimate is 1.3-fold (0.10 log units) below it, and the stated range covers the measured number.
By their numbers in this assay, from the lowest: compound 1; then compounds 3 and 2 (each within the scatter of the next).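

In this assay, the step of a 1.9-fold lower number from compound 2 to compound 3 (0.27 log units; within the scatter) shows that a five-membered 1-methyl-3-(trifluoromethyl)-1H-pyrazol-4-yl can stand in for 4-methoxyphenyl on this carbon with no clear change in the number. Trifluoromethyl alone does not settle the result, since the step of a 2.1-fold higher number from compound 1 to compound 3 (0.33 log units; beyond the scatter) separates two compounds that both carry it, so the ring holding it matters too. Nothing measured here offers a reason for either step. Still open, as far as these compounds go, is how an unsubstituted phenyl ring would compare, and whether an amine or a carboxylic acid on that ring would give a lower number.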